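Cytotoxicity limits as the pentyl chain shortens to propyl

This account rests on a few compounds, and the source may have more. Where it says the series, first, only, none or still open, it means among the compounds named here.

Compound 1 `CCCCCc1ccc(CCc2cc3cn([C@H]4C[C@H](O)[C@@H](CO)O4)c(=O)nc3o2)cc1` has no numerical value in an ADME assay on HEL cells (Homo sapiens) for cytotoxicity, with a stated time of 3 days; on this read-out higher numbers stand for lower toxicity in this test and lower numbers for higher toxicity in this test: compound 1 gives > 470000 nM, which is a limit. Compound 2 `CCCc1ccc(C#Cc2cc3cn([C@H]4C[C@H](O)[C@@H](CO)O4)c(=O)nc3o2)cc1` gives > 120000 nM, also a limit. Compound 3 `CCCc1ccc(CCc2cc3cn([C@H]4C[C@H](O)[C@@H](CO)O4)c(=O)nc3o2)cc1` differs from compound 1 by hydrogen in place of ethyl on a saturated chain carbon, three bonds along the chain from an aromatic carbon, or pentyl to propyl. Among the measured compounds shown here, no measured step is available, and no change beyond the scatter is expected in this assay. The expected step is an at least 1.5-fold lower number from compound 1 to compound 3 (0.19 log units; that floor lies within the scatter). For compound 3 the estimated value is 300000 nM, with an expected range of 100000 nM to 600000 nM.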

Compound 3, half-maximal cytotoxic concentration: > 130000 nM
Compound 3: only a limit was reported; the forecaster's own chance of this, stated with the estimate: 70%; the middle value lies beyond the limit too.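

Compound 1 and compound 3 both carry only limits in this assay, and no step can be read between them. The compounds shown leave open whether pentyl to propyl changes the half-maximal cytotoxic concentration at all.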